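Adding a methyl to the ring of compound 1

The source may report more compounds than this note shows. Statements on the series, on what has been measured and on what is new or still open speak of the compounds shown alone.

Measured compounds:
- compound 1, `Cc1cc(S(=O)(=O)/N=C(\N)n2nccc2-c2ccccc2)c(SCc2ccccc2Cl)cc1Cl`, 18000 nM
- compound 2, `Cc1cc(S(=O)(=O)/N=C(\N)n2nccc2-c2ccccc2)c(SCc2ccc(C(F)(F)F)cc2)cc1Cl`, 14000 nM
- compound 3, `Cc1cc(S(=O)(=O)/N=C(\N)n2nccc2-c2ccccc2)c(SCc2cccc3ccccc23)cc1Cl`, 7000 nM

In a functional assay on HCT-116 cells (Homo sapiens) for cytotoxicity, read by MTT assay, with a stated time of 72 h (a higher number here means a weaker inhibitor, a lower number a stronger inhibitor), compound 1 gives the highest of the three numbers. Its neighbours differ only in the group on the saturated chain carbon bound to a sulfur: a 1.3-fold lower number from compound 1 to compound 2 (0.11 log units; within the scatter) and a 2.6-fold lower number from compound 1 to compound 3 (0.41 log units; beyond the scatter), while a 2.0-fold lower number from compound 2 to compound 3 (0.30 log units; within the scatter).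

Compound 4, `Cc1cc(-c2ccccc2)n(/C(N)=N/S(=O)(=O)c2cc(C)c(Cl)cc2SCc2ccccc2Cl)n1`, is not yet measured. It differs from compound 1 in one place: methyl in place of hydrogen on an aromatic carbon.

Going by the values given here, none of the measured steps touches this ring; all three change the group on the sulfur-bound chain instead. So there is no measured step that bears on the change from compound 1 to compound 4, and the expectation rests on compound 1 alone. A single added methyl on an aromatic carbon is, without any evidence to the contrary, expected to give no step beyond the scatter, so for compound 4 the expected step is no change at the digits printed from compound 1 to compound 4 (within the scatter). Compound 4 is therefore estimated at 18000 nM, with a range from 8000 nM to 40000 nM.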

Compound 4, half-maximal inhibitory concentration: 170000 nM
Compound 4: the middle estimate sits 9.4-fold (0.98 log units) below what was measured, and the stated range ends below it.
By their numbers in this assay, from the lowest: compounds 3, 2 and 1 (each within the scatter of the next, the first and the last beyond it); then compound 4.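

In this assay, methyl in place of hydrogen on an aromatic carbon of the five-membered aromatic ring with 2 nitrogen gives a 9.4-fold higher number from compound 1 to compound 4 (0.98 log units; beyond the scatter), a larger step than any among compound 1, compound 2 and compound 3. Going by these compounds alone, the earlier compounds changed only the group on the sulfur-bound chain, so this is the first sign that the ring carbon matters, and that adding one heavy atom there can weaken the compound. No measurement shown here bears on why the number rises.

On these data alone, it remains open whether an ethyl group, a chlorine atom or an amine on this same carbon would weaken the compound as much. As far as these compounds go, it is also open whether the methyl would give a similar step with the naphthalen-1-yl group of compound 3 on the chain.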